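Pyridyl to carbamoylphenyl replacement in a biaryl benzamide series

The source may hold more compounds than are shown below. What is called first, only, known or untested is meant among the compounds shown, and "the series" means these compounds.

Measured compounds:
compound 1, `COc1ccc(C(=O)Nc2ccc(-c3ccncc3)cc2)cc1CCCN(C)C`, 10 nM
compound 2, `COc1ccc(NC(=O)c2ccc(-c3ccncc3)cc2)cc1N1CCN(C)CC1`, 5.01 nM
compound 3, `COc1ccc(C(=O)Nc2ccc(-c3ccc(-c4noc(C)n4)cc3C)cc2)cc1N1CCN(C)CC1`, 6.31 nM

In an assay on striatum for binding affinity to 5-hydroxytryptamine receptor 1D (Cavia porcellus), in the presence of a further agent that is not named here (on this read-out higher numbers stand for weaker inhibition and lower numbers for stronger inhibition), compound 2 gives 5.01 nM, the lowest of the three numbers, but its gaps to compound 3 and to compound 1 both lie within the usual scatter, so no order among the three can be read from these values. Among the measured compounds shown here, the three compounds share the biaryl benzamide layout and differ in more than one place, so no single-point step is available.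

Compound 4, `COc1ccc(NC(=O)c2ccc(-c3ccc(C(=O)N(C)C)cc3C)cc2)cc1N1CCN(C)CC1`, not yet measured, differs from compound 2 in one place: 4-(dimethylcarbamoyl)-2-methylphenyl in place of pyridin-4-yl on an aromatic carbon. The only related indication comes from compound 3, which also lacks pyridin-4-yl and in this assay gives 6.31 nM, a number within the scatter of compound 2; compound 3 differs elsewhere as well, so this is a weak guide. No step beyond the scatter is expected from the exchange. The step from compound 2 to compound 4 is estimated at a 1.6-fold higher number from compound 2 to compound 4 (0.20 log units; within the scatter), in either direction or none. Compound 4 is therefore expected at 8 nM, with a plausible range from 2.5 nM to 30 nM.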

Compound 4, inhibition constant: 5.01 nM
The estimate for compound 4 lay 1.6-fold (0.20 log units) above the measured number; the range from low to high includes it.
By their numbers in this assay, from the lowest: compounds 2, 4, 3 and 1 (each within the scatter of the next).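

In this assay, replacing pyridin-4-yl with 4-(dimethylcarbamoyl)-2-methylphenyl gives no change at the digits printed from compound 2 to compound 4 (within the scatter). Among the compounds shown here, this is the first comparison that isolates a single place, and it shows that this aromatic carbon, para to a large group, accepts a six-membered aromatic ring of carbon only in place of one with a hetero atom, with the substituent growing from 6 to 12 heavy atoms and no step beyond the scatter. Nothing available here gives a measured basis for explaining this result.

The methyl and the dimethylcarbamoyl group enter together, so the compounds shown leave open what each contributes alone and whether an unsubstituted phenyl ring would give a number in the same range. Also open, as far as these compounds go, is whether the position stays as accommodating with a charged or hydrogen-bond-donating group, such as a carboxylic acid or a primary amine, in place of the dimethylcarbamoyl group.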